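The source may report more compounds than this note shows. Statements on the series, on what has been measured and on what is new or still open speak of the compounds shown alone.

Working notes on the series in an ADME assay on S2 cells (Drosophila melanogaster) for cytotoxicity, read by MTT assay; a lower number here means that less compound is needed, a higher number that more compound is needed for the effect.

Compound 1 `O=C(/C=C/[C@H]1C[C@@H](O)[C@@H](O)C1)Nc1ccccc1` carries a phenyl on an amide-type nitrogen. In this assay compound 1 returns only a limit, > 200000 nM, so no number is known for it. Compound 2 `CNC(=O)/C=C/[C@H]1C[C@@H](O)[C@@H](O)C1` carries a methyl on that nitrogen instead; in this assay compound 2 likewise returns only a limit, > 250000 nM. Compound 3 `CCNC(=O)/C=C/[C@H]1C[C@@H](O)[C@@H](O)C1` carries an ethyl there, and in this assay compound 3 also returns only a limit, > 250000 nM. The steps a step that the two limits leave unreadable from compound 1 to compound 2, a step that the two limits leave unreadable from compound 1 to compound 3 and a step that the two limits leave unreadable from compound 2 to compound 3 are accordingly of unreadable size; all three values sit at the limit of > 200000 nM in this assay, at which 1 of the 3 values shown sits, or (the limit of > 250000 nM in this assay, at which 2 of the 3 values shown sit), and compound 1 stands at one of these limits with no number of its own.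

Compound 4 `O=C(/C=C/[C@H]1C[C@@H](O)[C@@H](O)C1)Nc1ccc(Cl)cc1` differs from compound 1 by chloro in place of hydrogen on an aromatic carbon. Within the data shown here, none of the measured steps touches the aromatic ring, so none bears directly on this change, and the three that exist are all unreadable, giving no size or direction to expect beyond the scatter. Compound 4 is expected at 200000 nM, with a range of 100000 nM to 400000 nM, most probably again as a limit only. The step of a number no higher from compound 1 to compound 4 (the limit leaves the size open) that this estimate means is expected to be none beyond the scatter.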

Compound 4, half-maximal effective concentration: > 180000 nM
Compound 4: no number, only a limit (the forecaster's own chance of this, stated with the estimate: 90%); the middle value does not contradict the limit.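

In this assay compound 4 returns only a limit, > 180000 nM. Compound 1 likewise has only a limit, so no step can be read between compound 1 and compound 4. The compounds shown leave open whether chloro in place of hydrogen on an aromatic carbon changes the value at all.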